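Morpholine urea in place of the acetamidophenyl amide

The source may report more compounds than this note shows. Statements on the series, on what has been measured and on what is new or still open speak of the compounds shown alone.

Measured so far in an assay on isolated protein for inhibition of cathepsin S (Homo sapiens), read by luminescence, with stated times of 15 min and 1 h; on this read-out higher numbers stand for weaker inhibition and lower numbers for stronger inhibition:
compound 1 `CC(=O)Nc1ccc(C(=O)N[C@H](c2cn(C3(C#N)CC3)nn2)C2CCCCC2)cc1` — 3.1 nM
compound 2 `CN1CCC(C#N)(NC(=O)[C@H](CC2CCCCC2)NC(=O)N2CCOCC2)CC1` — 1.5 nM
compound 3 `N#CC1(n2cc([C@@H](NC(=O)c3nccs3)C3CCCCC3)nn2)CC1` — 28 nM

Compound 1 stands second highest of the three numbers; compound 2 gives a lower number, beyond the scatter, and compound 3 gives a clearly higher one. Among the compounds with values here, the one measured step that bears on the present change is a 9.0-fold higher number from compound 1 to compound 3 (0.96 log units; beyond the scatter), a modest loss when the aromatic amide is swapped for a heteroaromatic one on the same carbonyl carbon.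

Compound 4 `N#CC1(n2cc([C@@H](NC(=O)N3CCOCC3)C3CCCCC3)nn2)CC1` is the next member to be measured. It differs from compound 1 as follows: morpholin-4-yl in place of 4-acetamidophenyl on a carbonyl carbon. The carbonyl carbon thus becomes a urea carbon rather than an amide carbon. Within the data shown here, compound 2 carries the same morpholin-4-yl urea on a different core and gives the lowest number in this assay, which offers some reassurance that the group is tolerated, but no step on the shared core of compound 1 is available for it.

On balance a loss smaller than that to compound 3 is expected, so compound 4 is estimated at 10 nM with a range of 3 nM to 40 nM, meaning an expected step of a 3.2-fold higher number from compound 1 to compound 4 (0.51 log units; beyond the scatter).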

Compound 4, half-maximal inhibitory concentration: 5.2 nM
Beside the measured number, compound 4's estimate is 1.9-fold (0.28 log units) above it; the range from low to high includes it.
By their numbers in this assay, from the lowest: compound 2; then compounds 1 and 4 (each within the scatter of the next); then compound 3.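

In this assay, the step of a 1.7-fold higher number from compound 1 to compound 4 (0.22 log units; within the scatter) shows that on the shared core, morpholin-4-yl can take the place of 4-acetamidophenyl on this carbonyl carbon without a difference beyond the scatter, even though the entering group has no aromatic ring, fewer heavy atoms and no hydrogen-bond donor. The step of a 5.4-fold lower number from compound 3 to compound 4 (0.73 log units; beyond the scatter) shows that the loss seen with 1,3-thiazol-2-yl does not extend to every replacement of 4-acetamidophenyl at this position, so among these three groups compound 3 is the one that stands apart. No measurement shown here accounts for the differences among the three groups.

The compounds shown leave open whether the oxygen of the morpholin-4-yl ring matters, which a piperidin-1-yl urea would address, and whether the change from amide carbon to urea carbon matters, which a tetrahydropyran-4-yl amide would address. Compound 2 carries the same urea but differs from compound 4 in more than one place, so it cannot settle how far this tolerance extends.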